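From Fluoro to Hydroxy: Estimating a Single Swap

A few compounds are considered here, and "the series" means these few. Any claim that something is new, unique, unknown or untested is made for them only; others in the source may bear on it.

In an ADME assay for permeability, using PAMPA, with a stated time of 3 h (on this read-out higher numbers stand for higher permeability and lower numbers for lower permeability), compound 2 `O=C(Nc1ccc(F)cc1)c1cc(Cl)ccc1O` gives 18.2 10^-6 cm/s, level with compound 1 `O=C(Nc1ccc(F)c(Cl)c1)c1cc(Cl)ccc1O` at 11.5 10^-6 cm/s. Compound 3 `O=C(Nc1cccc(F)c1)c1cc(Cl)ccc1O` gives 3.7 10^-6 cm/s, which leaves it well short of both. Compound 4 `O=C(Nc1ccc(O)cc1)c1cc(Cl)ccc1O` differs from compound 2 by hydroxy in place of fluoro on an aromatic carbon, which is hydroxy in place of fluoro on an aromatic carbon. Among the compounds with values here, the only measured single-place step is a 1.6-fold higher number from compound 1 to compound 2 (0.20 log units; within the scatter), and it swaps chloro for hydrogen, so it bears only loosely on this change. Within the data shown here, no measured compound carries the new hydroxy, but compound 3 at 3.7 10^-6 cm/s shows that this series can fall well short of compound 2. A drop is therefore expected, with an estimated step of a 3.6-fold lower number from compound 2 to compound 4 (0.56 log units; beyond the scatter). Compound 4 is estimated at 5 10^-6 cm/s, with an expected range of 1.5 10^-6 cm/s to 14 10^-6 cm/s.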

Compound 4, apparent permeability: 33.1 10^-6 cm/s
The estimate for compound 4 lay 6.6-fold (0.82 log units) below the measured number; measured number outside the range, above it.
By their numbers in this assay, from the lowest: compound 3; then compounds 1, 2 and 4 (each within the scatter of the next, the first and the last beyond it).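

In this assay the swap of fluoro for hydroxy on this aromatic carbon, para to a large group, gives a 1.8-fold higher number from compound 2 to compound 4 (0.26 log units; within the scatter) and so leaves the number level. Within the data shown here, a hydrogen-bond donor and a hydrogen-bond acceptor thus enter at this place with no step beyond the scatter, something the earlier compounds, none of which carries hydroxy, could not show. No measurement at hand gives a reason for this result.

From the compounds shown here alone, whether an amine or a carboxylic acid at this same place would also stay level with compound 2 remains open.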